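The source may hold more compounds than are shown below. What is called first, only, known or untested is meant among the compounds shown, and "the series" means these compounds.

Of the compounds shown here, three have so far been measured in a functional assay on the whole organism (plasma, strain Sprague-Dawley) with Rattus norvegicus as the target, with a stated time of 2 h, at a dose of 100 mg/kg by the oral route; a lower number here means a weaker effect, a higher number a stronger effect of the compound at the dose given. Compound 1 `c1ccc(C(/N=C2\CCCCCN2)C2CCC2)cc1` gives 44% in this assay, the second highest of the three numbers. Compound 2 `c1csc(C(/N=C2\CCCCCCN2)C2CC2)c1` gives 50%, a number within the usual scatter of the number of compound 1, so the two cannot be told apart. Compound 3 `c1ccc(C(/N=C2\CCCCN2)c2ccco2)cc1` gives 27%, a number that lies beyond the scatter below compound 1. No two of these compounds differ in only one place, so no measured step is available. Compound 4 `c1ccc(C(/N=C2\CCCCCN2)c2cccs2)cc1` has not yet been measured. It differs from compound 1 by thiophen-2-yl in place of cyclobutyl on a saturated chain carbon bound to an aromatic carbon and a double-bonded nitrogen. The step is expected to be small, a number 6 percentage points lower from compound 1 to compound 4 (within the scatter), and probably not beyond the scatter. Compound 4 is therefore estimated to give about 38% in this assay, within a range from 20% to 58%.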

Compound 4, a percentage reported as inhibition, in the whole organism at one dose (the size of the read-out at that dose, not a potency): 50%
Beside the measured number, compound 4's estimate is 12 percentage points below it; the range from low to high includes it.
By their numbers in this assay, from the lowest: compound 3; then compounds 1, 2 and 4 (each within the scatter of the next).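

At the saturated chain carbon bound to an aromatic carbon and a double-bonded nitrogen, replacing cyclobutyl with thiophen-2-yl in this assay gives a number 6 percentage points higher from compound 1 to compound 4 (within the scatter) and so leaves the two compounds indistinguishable. This first measured step shows that, on this core and at this dose, a non-aromatic carbon ring and an aromatic sulfur-containing ring at this position give numbers that cannot be told apart. Nothing available explains this match. Still open, as far as these compounds go, is whether an open isopropyl chain, an amine or a carboxylic acid at this carbon would give a similar number.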